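Benzoyl replacing a hydroxylated phenylpropyl on the ring nitrogen

A few compounds are considered here, and "the series" means these few. Any claim that something is new, unique, unknown or untested is made for them only; others in the source may bear on it.

Compound 1 `Fc1ccc(CN2CCC(NCCSC(c3ccc(F)cc3)c3ccc(F)cc3)CC2)cc1` gives 980 nM in an assay on membranes from HEK293 cells for displacement of a labelled ligand from D(4) dopamine receptor (Homo sapiens), read by scintillation counting, with a stated time of 60 min; on this read-out lower numbers stand for stronger inhibition and higher numbers for weaker inhibition.
Compound 2 `OC(Cc1ccccc1)CN1CCC(NCCSC(c2ccc(F)cc2)c2ccc(F)cc2)CC1` gives 2200 nM in this assay.

Among the compounds with values here, compound 2 stands at the higher of the two numbers measured so far: the step of a 2.2-fold higher number from compound 1 to compound 2 (0.35 log units; beyond the scatter) is modest but beyond the scatter. Compound 3 `O=C(c1ccccc1)N1CCC(NCCSC(c2ccc(F)cc2)c2ccc(F)cc2)CC1` differs from compound 2 by the change (benzoyl in place of 2-hydroxy-3-phenylpropyl on an amine nitrogen in a ring). Within the data shown here, no measured step covers a benzoyl at this position; the only step that touches the same ring nitrogen is a 2.2-fold higher number from compound 1 to compound 2 (0.35 log units; beyond the scatter), which swapped one substituent for another and moved the number only modestly. The groundwork is therefore thin. The closest available comparison, the step from compound 1 to compound 2, suggests that changes at this nitrogen shift this assay by small amounts, so compound 3 is expected to land near compound 2, with a slight drift upward allowed: a 1.8-fold higher number from compound 2 to compound 3 (0.26 log units; within the scatter). The estimate for compound 3 is 4000 nM, with a range from 1200 nM to 15000 nM.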

Compound 3, inhibition constant: 4110 nM
Compound 3: the middle estimate sits 1.0-fold (0.01 log units) below what was measured, and the stated range covers the measured number.
By their numbers in this assay, from the lowest: compound 1; then compounds 2 and 3 (each within the scatter of the next).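

In this assay, benzoyl in place of 2-hydroxy-3-phenylpropyl on the amine nitrogen in the ring gives a 1.9-fold higher number from compound 2 to compound 3 (0.27 log units; within the scatter) and so leaves compound 3 indistinguishable from compound 2, even though benzoyl lacks the hydrogen-bond donor of the group it replaces. Measured against 4-fluorobenzyl at the same nitrogen, benzoyl gives a 4.2-fold higher number from compound 1 to compound 3 (0.62 log units; beyond the scatter) and this is the largest step at this position among the three compounds, still modest but beyond the scatter. Nothing available explains either step.

Compound 1 and compound 3 differ in both the ring fluorine and the carbonyl, so a plain benzyl or a 4-fluorobenzoyl would be needed to separate the two. From the compounds shown here alone, whether a free ring amine or a phenylacetyl group would fall closer to compound 1 also remains open.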